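The compounds below may be only part of what the source reports. "The series", "measured", "known", "first", "only" and "open" are said of these compounds alone.

Measured so far in an ADME assay on L6 cells (Rattus norvegicus) for cytotoxicity, read by resazurin assay, with a stated time of 70 h; a higher number here means a weaker inhibitor, a lower number a stronger inhibitor:

Compound 1, `CC1=CC(C)(C)N(Cc2ccc(Cl)cc2)c2ccc(O)cc21`, gives 7900 nM.
Compound 2, `CC1=CC(C)(C)N(Cc2ccc(C)cc2)c2ccc(O)cc21`, gives 8100 nM.
Compound 3, `CC(=O)Oc1ccc2c(c1)C(C)=CC(C)(C)N2Cc1ccc(Cl)cc1`, gives 22000 nM.

Compound 2 is reached from compound 1 by one change, (methyl in place of chloro on an aromatic carbon), and the step it made was a 1.0-fold higher number from compound 1 to compound 2 (0.01 log units; within the scatter). Compound 3 is reached from compound 1 by a different change, (acetyl in place of hydrogen on an oxygen on an aromatic ring), and that step was a 2.8-fold higher number from compound 1 to compound 3 (0.44 log units; beyond the scatter), which leaves compound 3 with the highest of the three numbers.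

Compound 4, `CC(=O)Oc1ccc2c(c1)C(C)=CC(C)(C)N2Cc1ccc(C)cc1`, has not yet been measured. It differs from compound 3 by methyl in place of chloro on an aromatic carbon. For the measured compounds named here, this is the same change as the one from compound 1 to compound 2, made on the core of compound 3 instead of the core of compound 1; the two cores differ by acetyl in place of hydrogen on an oxygen on an aromatic ring.

Because the step of a 1.0-fold higher number from compound 1 to compound 2 (0.01 log units; within the scatter) stayed within the scatter, the expected step here is no change at the digits printed from compound 3 to compound 4 (within the scatter), resting on that one earlier pair alone. Compound 4 is therefore expected to give about 22000 nM, estimated to fall between 11000 nM and 44000 nM.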

Compound 4, half-maximal inhibitory concentration: 21000 nM
For compound 4 the middle estimate is 1.0-fold (0.02 log units) above the measured one; low and high end bracket the measured number.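

In this assay, the swap of chloro for methyl also stayed within the scatter on the acetyl-bearing core, with a 1.0-fold lower number from compound 3 to compound 4 (0.02 log units; within the scatter), and this agrees with the step on the hydroxyl-bearing core: the same change on two cores in this assay, a 1.0-fold higher number (0.01 log units; within the scatter) from compound 1 to compound 2 and a 1.0-fold lower number (0.02 log units; within the scatter) from compound 3 to compound 4, 1.1-fold (0.03 log units) apart, within the scatter of two such steps. The acetyl change likewise carried over to the methyl-bearing compounds, with a 2.6-fold higher number from compound 2 to compound 4 (0.41 log units; beyond the scatter), a step beyond the scatter that agrees with the one seen on the chloro-bearing compounds: the same change on two cores in this assay, a 2.8-fold higher number (0.44 log units; beyond the scatter) from compound 1 to compound 3 and a 2.6-fold higher number (0.41 log units; beyond the scatter) from compound 2 to compound 4, 1.1-fold (0.03 log units) apart, within the scatter of two such steps. Across these four compounds, the two changes therefore appear to act independently, but two pairs per change do not show that this holds beyond them, and they do not explain why either step has the size it has.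

The compounds shown leave open whether a different group on the benzyl ring, such as an amine or a carboxylic acid, would also make no difference beyond the scatter. They also leave open whether a longer ester chain or a methyl ether on the oxygen would give a step like that of the acetyl group.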